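Removing the Amino Group from a Potent Ester Agonist

The source may hold more compounds than are shown below. What is called first, only, known or untested is meant among the compounds shown, and "the series" means these compounds.

Compound 1, `CCCCCCCCCCCOC(=O)[C@H](N)CCC(=O)NC(CCCC(N)C(=O)O)C(=O)O`, was tested in a functional assay on HEK293 cells for agonist activity at Nucleotide-binding oligomerization domain-containing protein 1 (Homo sapiens), read by spectrophotometry (on this read-out higher numbers stand for an effect only at larger amounts of compound and lower numbers for an effect already at smaller amounts), where compound 1 gives 0.066 nM. Two other compounds have been measured in the same way. Compound 2, `CCCCCCCCCCCNC(=O)[C@H](N)CCC(=O)NC(CCCC(N)C(=O)O)C(=O)O`, gives 0.826 nM in this assay. Compound 3, `CCCCCCCCCCCC(=O)NCCCC(=O)NC(CCCC(N)C(=O)O)C(=O)O`, gives 0.504 nM in this assay. Compound 1 thus holds the lowest number of the three, and its gaps to compound 3, the nearest, and to compound 2, the furthest, both lie beyond the usual scatter of repeated measurements, so compound 1 is the most potent of the set.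

Compound 4, `CCCCCCCCCCCOC(=O)CCCC(=O)NC(CCCC(N)C(=O)O)C(=O)O`, has not yet been measured. It differs from compound 1 in one place: hydrogen in place of amino on a saturated chain carbon bound to a carbonyl carbon and a saturated chain carbon. Within the data shown here, no measured pair isolates this change, so the direction can only be judged loosely. Compound 3 also lacks that amino group and gives 0.504 nM, a higher number than compound 1, but compound 3 differs from compound 1 in more than one place, so it is only a rough guide. The step from compound 1 to compound 4 is expected to be a 4.5-fold higher number from compound 1 to compound 4 (0.66 log units; beyond the scatter), a moderate rise beyond the scatter. Compound 4 is therefore estimated at 0.3 nM, with a range from 0.06 nM to 2 nM.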

Compound 4, half-maximal effective concentration: 0.39 nM
The estimate for compound 4 lay 1.3-fold (0.11 log units) below the measured number; low and high end bracket the measured number.
By their numbers in this assay, from the lowest: compound 1; then compounds 4, 3 and 2 (each within the scatter of the next, the first and the last beyond it).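

Among these compounds, compound 1 and compound 4 are the first pair here that differ in one place only, so the amino group on this saturated chain carbon, bound to a carbonyl carbon and a saturated chain carbon, can now be judged on its own. In this assay, hydrogen in place of amino gives a 5.9-fold higher number from compound 1 to compound 4 (0.77 log units; beyond the scatter), so in this ester the amino group goes with an effect at smaller amounts of compound, and losing it has a modest but real cost. Even so, the amino group is not essential for activity, as compound 4 still gives 0.39 nM. The data shown offer no evidence on why this step occurs.

Going by these compounds, it remains open whether a different group at this place, such as a hydroxyl or a methylamino group, would keep the number of compound 1 or give a rise like that seen with hydrogen. On these data alone, it is also open whether the same replacement in compound 2, which carries an amide in place of the ester, would give a step of similar size.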